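The source may report more compounds than this note shows. Statements on the series, on what has been measured and on what is new or still open speak of the compounds shown alone.

Compound 1 `COc1cc2ncnc(Nc3cccc(Br)c3)c2cc1OCCCCC(=O)Nc1ccc(S(N)(=O)=O)cc1` gives 9750 nM in a functional assay on A-431 cells (Homo sapiens) for antiproliferative activity, read by MTT assay, with a stated time of 72 h; a higher number here means a weaker inhibitor, a lower number a stronger inhibitor. Compound 2 `COc1cc2ncnc(Nc3ccc(Cl)cc3)c2cc1OCCCCC(=O)Nc1ccc(S(N)(=O)=O)cc1` gives 7120 nM. Compound 3 `COc1cc2ncnc(Nc3ccc(F)c(Br)c3)c2cc1OCCCCC(=O)Nc1ccc(S(N)(=O)=O)cc1` gives 8020 nM.

Compound 3 stands second highest of the three numbers, though all three lie within the scatter of one another. Compound 4 `COc1cc2ncnc(Nc3ccc(OC(F)(F)F)cc3)c2cc1OCCCCC(=O)Nc1ccc(S(N)(=O)=O)cc1` differs from it in one place: 4-(trifluoromethoxy)phenyl in place of 3-bromo-4-fluorophenyl on a nitrogen on an aromatic ring. Two measured steps also exchange the aryl group on that nitrogen, a 1.4-fold lower number from compound 1 to compound 2 (0.14 log units; within the scatter) and a 1.1-fold higher number from compound 2 to compound 3 (0.05 log units; within the scatter), and neither moved the number beyond the scatter. On that footing no step beyond the scatter is expected for compound 4 in this assay, the estimated change being a 1.0-fold lower number from compound 3 to compound 4 (0.00 log units; within the scatter). Compound 4 is therefore expected to give about 8000 nM, with a likely range from 4000 nM to 16000 nM.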

Compound 4, half-maximal inhibitory concentration: 22500 nM
Estimate against measurement, compound 4: 2.8-fold (0.45 log units) below, outside the stated range (above it).
By their numbers in this assay, from the lowest: compounds 2, 3 and 1 (each within the scatter of the next); then compound 4.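

In this assay the aryl group on the nitrogen can move the number beyond the scatter: 4-(trifluoromethoxy)phenyl gives a 2.8-fold higher number from compound 3 to compound 4 (0.45 log units; beyond the scatter) and a 3.2-fold higher number from compound 2 to compound 4 (0.50 log units; beyond the scatter) and a 2.3-fold higher number from compound 1 to compound 4 (0.36 log units; beyond the scatter) with each step modest. Exchanges among the 3-bromophenyl, 4-chlorophenyl and 3-bromo-4-fluorophenyl groups had stayed within the scatter. No measurement at hand explains this change. From the compounds shown here alone, whether a methoxy or a trifluoromethyl group on that phenyl ring would give a number near that of compound 4 or near those of the other three compounds remains open.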